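The source may hold more compounds than are shown below. What is called first, only, known or untested is meant among the compounds shown, and "the series" means these compounds.

Three compounds have so far been run in a functional assay on NIH3T3 cells (Mus musculus); a higher number here means that more compound is needed for the effect, a lower number that less compound is needed. Compound 1, `CSCC[C@H](NC(=O)c1ccc(NCc2cncn2Cc2ccccc2C)cc1-c1ccccc1)C(=O)O`, gives in this assay only a limit, > 10 uM, not a number. Compound 2, `CCOC(=O)[C@H](CCSC)NC(=O)c1ccc(CNCc2c[nH]cn2)cc1-c1ccccc1C`, gives in this assay 10 uM. Compound 3, `COC(=O)[C@H](CCSC)NC(=O)c1ccc(NCc2cncn2Cc2cccc([N+](=O)[O-])c2)cc1-c1ccccc1`, likewise reaches in this assay only a limit, > 10 uM, which is no number either. Compound 3 thus stands at the limit of > 10 uM in this assay, at which 2 of the 3 values shown sit.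

The next compound is compound 4, `COC(=O)[C@H](CCSC)NC(=O)c1ccc(NCc2cncn2Cc2ccc([N+](=O)[O-])cc2)cc1-c1ccccc1`. It holds the same atoms as compound 3, joined differently: 4-nitrophenyl in place of 3-nitrophenyl on a saturated chain carbon bound to an aromatic nitrogen. Cut one bond further out, the same change reads 3-nitrobenzyl to 4-nitrobenzyl.

Going by the values given here, no two measured compounds differ in one place only, so no measured step shows how such a swap moves this assay. Compound 3 stands at a limit, and a shift in either direction would be hard to see from there. The step is expected to be no larger than the scatter, with a step that the limit leaves unreadable from compound 3 to compound 4 as the expected size. Compound 4 is therefore expected to give in this assay about 15 uM, with a range from 5 uM to 60 uM, and most likely once more only a limit rather than a number.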

Compound 4, concentration for half-maximal effect: > 10 uM
Compound 4 gave a limit, no number; the forecaster's own chance of this, stated with the estimate: 65%; the middle value lies beyond the limit too.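

Compound 3 and compound 4 each give only a limit in this assay, not a number, so the change from 3-nitrobenzyl to 4-nitrobenzyl yields no readable step. The compounds shown leave open whether this change moves this assay at all, with most values shown resting on one limit: the limit of > 10 uM in this assay, at which 3 of the 4 values shown sit.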